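Replacing the Furan Ring with Oxolane in Compound 4

The source may hold more compounds than are shown below. What is called first, only, known or untested is meant among the compounds shown, and "the series" means these compounds.

Compound 3 `Nc1nc(-c2ccc(C(F)F)o2)nc2sc(Cc3ccccc3)cc12` gives 3000 nM in a functional assay on CHO-K1 cells for antagonist activity at adenosine receptor A1 (Homo sapiens), read by a beta-galactosidase reporter and cAMP accumulation, with stated times of 15 min and 6 h (a lower number here means a stronger inhibitor, a higher number a weaker inhibitor), the second highest of three numbers: compound 2 `N#Cc1ccc(-c2nc(N)c3cc(Cc4ccccc4)sc3n2)o1` gives 3160 nM, a gap within the scatter, while compound 1 `Nc1nc(-c2ccc(C3CC3)o2)nc2sc(Cc3ccccc3)cc12` gives 861 nM, the lowest of the three. Compound 4 `Nc1nc(C2CCCO2)nc2sc(Cc3ccccc3)cc12` differs from compound 3 in one place: oxolan-2-yl in place of 5-(difluoromethyl)furan-2-yl on an aromatic carbon. The measured steps all alter only the group carried on the furan-2-yl ring: a 3.7-fold higher number from compound 1 to compound 2 (0.56 log units; beyond the scatter) and a 3.5-fold higher number from compound 1 to compound 3 (0.54 log units; beyond the scatter) were modest, and a 1.1-fold lower number from compound 2 to compound 3 (0.02 log units; within the scatter) lay within the scatter. None of them exchanges the aromatic ring itself, so the size of the change is not covered by any measured step; a higher number is nonetheless expected for compound 4, with the step of a 2.0-fold higher number from compound 3 to compound 4 (0.30 log units; within the scatter). Compound 4 is therefore estimated at 6000 nM, with a range from 1500 nM to 25000 nM.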

Compound 4, inhibition constant: 2950 nM
Estimate against measurement, compound 4: 2.0-fold (0.31 log units) above, and the stated range covers the measured number.
By their numbers in this assay, from the lowest: compound 1; then compounds 4, 3 and 2 (each within the scatter of the next).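

In this assay, the non-aromatic oxolan-2-yl, with no substituent, can take the place of a substituted furan-2-yl on this aromatic carbon and stay within the scatter of two of the furan compounds: a 1.0-fold lower number from compound 3 to compound 4 (0.01 log units; within the scatter) and a 1.1-fold lower number from compound 2 to compound 4 (0.03 log units; within the scatter). Only the 5-cyclopropylfuran-2-yl group stands apart, with a 3.4-fold higher number from compound 1 to compound 4 (0.53 log units; beyond the scatter). No measurement is available that explains these results.

On these data alone, because each exchange removes the furan ring and its substituent together, the contribution of each remains open. Also open, as far as these compounds go, is how a cyclopropyl group on the oxolane ring, or an amine in place of that ring, would read here.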